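The source may report more compounds than this note shows. Statements on the series, on what has been measured and on what is new or still open speak of the compounds shown alone.

Measured in a functional assay on MCF7 cells (Homo sapiens) for inhibition, read by MTT assay; on this read-out higher numbers stand for weaker inhibition and lower numbers for stronger inhibition:
Compound 1 `COc1cc2ncnc(Nc3ccc(NC(=O)c4cccc(C)c4)cc3)c2cc1OC`: 13000 nM
Compound 2 `COc1cc2ncnc(Nc3ccc(NC(=O)c4cccc(Cl)c4)cc3)c2cc1OC`: 18000 nM
Compound 3 `COc1cc2ncnc(Nc3ccc(NC(=O)c4ccc(Cl)cc4)cc3)c2cc1OC`: 30000 nM

Compound 3 reads 30000 nM, the high-number side of this small set. It cannot be separated from its closest neighbour, as the data show a 1.7-fold higher number from compound 2 to compound 3 (0.22 log units; within the scatter). It does stand apart from the remaining one, with a 2.3-fold higher number from compound 1 to compound 3 (0.36 log units; beyond the scatter).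

Compound 4 `COc1cc2ncnc(Nc3ccc(NC(=O)c4ccc(Cl)c(Cl)c4)cc3)c2cc1OC` makes a single change to compound 3: chloro in place of hydrogen on an aromatic carbon, ortho to a chloro group and meta to a large group (chloro in place of hydrogen on an aromatic carbon). This turns 4-chlorophenyl to 3,4-dichlorophenyl.

Among the measured compounds shown here, no measured step adds a substituent in this way, so the evidence is indirect. The nearest guides are changes of group on the same ring, which stayed small: a 1.4-fold higher number from compound 1 to compound 2 (0.14 log units; within the scatter), and again a 1.7-fold higher number from compound 2 to compound 3 (0.22 log units; within the scatter). On that basis, no shift beyond the scatter is expected in this assay, in either direction. The estimated change is a 1.4-fold lower number from compound 3 to compound 4 (0.13 log units; within the scatter).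

For compound 4 the expected value is 22000 nM, with an estimated range of 9000 nM to 50000 nM.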

Compound 4, half-maximal inhibitory concentration: 25000 nM
Compound 4: the middle estimate sits 1.1-fold (0.06 log units) below what was measured; the range from low to high includes it.
By their numbers in this assay, from the lowest: compounds 1, 2, 4 and 3 (each within the scatter of the next, the first and the last beyond it).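

Adding a second chloro to the ring of compound 3, ortho to a chloro group and meta to a large group, is the first step here that adds a substituent rather than exchanging one, and in this assay the two compounds cannot be separated: a 1.2-fold lower number from compound 3 to compound 4 (0.08 log units; within the scatter). The 3,4-dichlorophenyl group also cannot be separated from the singly substituted rings of the other two compounds, with a 1.4-fold higher number from compound 2 to compound 4 (0.14 log units; within the scatter) and a 1.9-fold higher number from compound 1 to compound 4 (0.28 log units; within the scatter). Compound 4 therefore lies within the scatter of all three other compounds, so this added chloro gives no readable gain or loss, and no supporting data speak to the reason.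

Still open, as far as these compounds go, is how this position responds to groups of a different kind, such as an amine, a carboxylic acid or a methoxy group. Also open, from the compounds shown here alone, is whether any change on this ring can give clearly stronger inhibition than these four compounds show.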